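Working notes on a thiazolyl hydrazone pair, single aryl exchange

The compounds below may be only part of what the source reports. "The series", "measured", "known", "first", "only" and "open" are said of these compounds alone.

Two compounds of the series have numbers in a functional assay on U-87MG ATCC cells for inhibition, with U-87 MG (Homo sapiens) as the target, read by MTT assay, with a stated time of 48 h; on this read-out lower numbers stand for stronger inhibition and higher numbers for weaker inhibition. Compound 1, `Fc1ccc(/C=N/Nc2nc(-c3cc(C(F)(F)F)cc(C(F)(F)F)c3)cs2)cc1F`, gives 29700 nM in this assay. Compound 2, `COc1cc(/C=N/Nc2nc(-c3ccc(Br)cc3)cs2)cc(Br)c1OC`, gives 27900 nM in this assay. Within the data shown here, the two numbers lie within the usual scatter of each other, so neither compound can be set apart from the other on these data, and no step between them is computed.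

Compound 3, `COc1cc(/C=N/Nc2nc(-c3ccc(F)c(F)c3)cs2)cc(Br)c1OC`, is not yet measured in this assay. It differs from compound 2 in one place: 3,4-difluorophenyl in place of 4-bromophenyl on an aromatic carbon. Among the measured compounds shown here, no measured pair shows what an exchange of this kind does, so there is no basis for expecting a step in either direction beyond the scatter. Compound 3 is therefore expected to sit close to compound 2, with the step from compound 2 to compound 3 estimated as a 1.1-fold higher number from compound 2 to compound 3 (0.03 log units; within the scatter). The estimate for compound 3 in this assay is 30000 nM, with a range from 10000 nM to 90000 nM.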

Compound 3, half-maximal inhibitory concentration: 26300 nM
Compound 3: middle estimate off by 1.1-fold (0.06 log units), on the high side; the measured number falls inside the stated range.
By their numbers in this assay, from the lowest: compounds 3, 2 and 1 (each within the scatter of the next).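

In this assay, the exchange of 4-bromophenyl for 3,4-difluorophenyl gives a 1.1-fold lower number from compound 2 to compound 3 (0.03 log units; within the scatter), so compound 2 and compound 3 cannot be told apart on this read-out. This is the only pair shown that differs in one place, and it gives the series its first direct reading at this position, on an aromatic carbon of the five-membered aromatic ring, next to the ring nitrogen: with the rest of the structure held fixed, these two halogen-bearing phenyl groups read alike. The data shown offer no explanation for this equivalence.

Open, going by these compounds, is whether a group of a different kind at this position, such as a carboxylic acid, an amine or a longer alkyl chain, would give a step beyond the scatter, since both groups compared here are halogen-bearing phenyl rings. Also open, on these data alone, is what the bromine and methoxy groups on the other aryl ring contribute, for instance whether a hydroxyl group in place of a methoxy group would alter the reading.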